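A few compounds are considered here, and "the series" means these few. Any claim that something is new, unique, unknown or untested is made for them only; others in the source may bear on it.

In a functional assay on RPMI 8402 cells (Homo sapiens) for cytotoxicity (on this read-out lower numbers stand for stronger inhibition and higher numbers for weaker inhibition), compound 1 `N#Cc1ccc2[nH]c(-c3ccc4[nH]c(-c5ccc6[nH]cnc6c5)nc4c3)nc2c1` reads > 25000 nM, which is a limit of the assay and not a number. Compound 1 sits at the limit of > 25000 nM in this assay, at which 1 of the 2 values shown sits. Going by the values given here, compound 2 `CCCc1ccc2[nH]c(-c3ccc4[nH]c(-c5ccc6[nH]cnc6c5)nc4c3)nc2c1` gives 7600 nM, the only true number so far. The structural change now in question leads to compound 3 `c1ccc(-c2ccc3[nH]c(-c4ccc5[nH]c(-c6ccc7[nH]cnc7c6)nc5c4)nc3c2)cc1`, which carries phenyl in place of propyl on an aromatic carbon. Among the compounds with values here, only one measured step bears on this carbon: propyl in place of cyano gave an at least 3.2-fold lower number from compound 1 to compound 2 (0.51 log units; beyond the scatter), a change beyond the scatter, showing that this assay responds to what sits there. Within the data shown here, that step rests on a limit, and no aromatic ring has yet been tested at this carbon, so it is a loose guide. Even so, a further move towards a lower number is expected, of a size comparable to or somewhat greater than that of the step to compound 2. The expected change is a 6.3-fold lower number from compound 2 to compound 3 (0.80 log units; beyond the scatter). For compound 3 the estimated value is 1200 nM, with an expected range from 150 nM to 7000 nM.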

Compound 3, half-maximal inhibitory concentration: 90 nM
Compound 3: the middle estimate sits 13-fold (1.12 log units) above what was measured; measured number outside the range, below it.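

In this assay, going by these compounds alone, this aromatic carbon proves highly sensitive to the nature of its substituent: phenyl in place of propyl gives an 84-fold lower number from compound 2 to compound 3 (1.93 log units; beyond the scatter), so a six-membered aromatic ring of carbon only goes with a large drop where the earlier compounds carried only a nitrile or a chain without a ring. Phenyl in place of cyano gives an at least 270-fold lower number from compound 1 to compound 3 (2.44 log units; beyond the scatter), and the three groups fall in the order cyano, propyl, phenyl, from the highest number to the lowest, with no compound shown going against this order. The size of that second step remains a bound, as compound 1 stands at a limit of the assay and not at a number: the limit of > 25000 nM in this assay, at which 1 of the 3 values shown sits.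

Phenyl differs from propyl both in being a ring and in its larger count of heavy atoms, and the compounds shown do not separate the two, a question on which a saturated ring such as cyclohexyl or a longer chain such as hexyl would bear. Also open, as far as these compounds go, is whether the low number depends on the ring being all carbon, as a pyridine ring would test, or whether it survives a methoxy group or an amine on the phenyl.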